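This account rests on a few compounds, and the source may have more. Where it says the series, first, only, none or still open, it means among the compounds named here.

- Compound 1 `Cc1cc(C(F)(F)F)ccc1-c1cc2cnn([C@@H](CC(C)C)c3ccc(C(=O)NCCC(=O)O)cc3)c2cc1C`: 1.61 mL/min/kg
- Compound 2 `Cc1cc(C(F)(F)F)ccc1-c1cc2cn([C@@H](CC(C)C)c3ccc(C(=O)NCCC(=O)O)cc3)nc2cc1C`: 4.78 mL/min/kg

In an ADME assay on the whole organism (Mus musculus, strain C57) for pharmacokinetics (a higher number here means faster removal of the compound, a lower number slower removal), compound 1 stands lowest of the two measured compounds at 1.61 mL/min/kg, and compound 2 gives 4.78 mL/min/kg, a gap that lies beyond the scatter. Compound 3 `Cc1cc2c(cnn2[C@@H](CC(C)C)c2ccc(C(=O)NCCC(=O)O)cc2)cc1-c1ccc(C(F)(F)F)cc1Cl` has not yet been measured. It differs from compound 1 at one place: chloro in place of methyl on an aromatic carbon, ortho to a large group, meta to a trifluoromethyl group. Within the data shown here, no measured pair shows this change, so no step beyond the scatter is expected in either direction. The expected change is a 1.0-fold lower number from compound 1 to compound 3 (0.00 log units; within the scatter). For compound 3 the estimated clearance is 1.6 mL/min/kg, with an expected range of 0.9 mL/min/kg to 3 mL/min/kg.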

Compound 3, clearance: 2.47 mL/min/kg
Compound 3: middle estimate off by 1.5-fold (0.19 log units), on the low side, within the range that was stated.
By their numbers in this assay, from the lowest: compounds 1, 3 and 2 (each within the scatter of the next, the first and the last beyond it).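

In this assay, the change from 2-methyl-4-(trifluoromethyl)phenyl to 2-chloro-4-(trifluoromethyl)phenyl gives a 1.5-fold higher number from compound 1 to compound 3 (0.19 log units; within the scatter). This first pair differing in one place shows that chloro can stand in place of methyl at this position with no step beyond the scatter. Nothing available explains this result.

The compounds shown leave open how a fluoro, methoxy or nitrile group would read at this position. They also leave open whether chloro in place of methyl gives a similar step on the core of compound 2.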